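Trimethoxyphenyl to Methoxyphenyl on a Second Core

The source may hold more compounds than are shown below. What is called first, only, known or untested is meant among the compounds shown, and "the series" means these compounds.

Measured compounds:
Compound 1 `COc1cc(C(=O)c2ccc3c(ccn3S(=O)(=O)c3cccc(/C=C/C(=O)NO)c3)c2)cc(OC)c1OC` — 1260 nM
Compound 2 `COc1ccc(C(=O)c2ccc3c(ccn3S(=O)(=O)c3cccc(/C=C/C(=O)NO)c3)c2)cc1` — 812 nM
Compound 3 `COc1cc(C(=O)c2ccc3c(ccn3Cc3ccc(/C=C/C(=O)NO)cc3)c2)cc(OC)c1OC` — 2170 nM

In an assay on isolated protein for inhibition of histone deacetylase 8 (Homo sapiens) (a higher number here means a weaker inhibitor, a lower number a stronger inhibitor), compound 1 gives 1260 nM and compound 2 gives 812 nM. The two differ by 4-methoxyphenyl in place of 3,4,5-trimethoxyphenyl on a carbonyl carbon, and that change made a step of a 1.6-fold lower number from compound 1 to compound 2 (0.19 log units; within the scatter). Compound 3 gives 2170 nM; the difference between its core and the core of compound 1 is not broken down here, and its value lies within the scatter of compound 1 but beyond the scatter of compound 2.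

Compound 4 `COc1ccc(C(=O)c2ccc3c(ccn3Cc3ccc(/C=C/C(=O)NO)cc3)c2)cc1` has not yet been measured. It differs from compound 3 by the same change, (4-methoxyphenyl in place of 3,4,5-trimethoxyphenyl on a carbonyl carbon), at the same place. Because the earlier step of a 1.6-fold lower number from compound 1 to compound 2 (0.19 log units; within the scatter) lay within the scatter, only a small shift is expected here as well. For compound 4 the expected step is a 1.6-fold lower number from compound 3 to compound 4 (0.19 log units; within the scatter). The estimate for compound 4 in this assay is 1400 nM, expected to fall between 600 nM and 3500 nM.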

Compound 4, half-maximal inhibitory concentration: 2810 nM
Compound 4: the middle estimate sits 2.0-fold (0.30 log units) below what was measured; the measured number falls inside the stated range.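

In this assay, putting 4-methoxyphenyl in place of 3,4,5-trimethoxyphenyl on a carbonyl carbon gave a 1.3-fold higher number from compound 3 to compound 4 (0.11 log units; within the scatter). Set beside the same change on the other core, this step cannot be told apart from the earlier one: the same change on two cores in this assay, a 1.6-fold lower number (0.19 log units; within the scatter) from compound 1 to compound 2 and a 1.3-fold higher number (0.11 log units; within the scatter) from compound 3 to compound 4, 2.0-fold (0.30 log units) apart, within the scatter of two such steps. The change thus stays within the scatter on both cores, but this does not show that it has any real effect on either core, nor that it would stay as small on a third core.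

The compounds shown leave open what a larger change at this place would do, such as an unsubstituted phenyl, a pyridine ring or a phenyl carrying an amine. They also leave open how the change reads on any other histone deacetylase.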